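The source may report more compounds than this note shows. Statements on the series, on what has been measured and on what is new or still open speak of the compounds shown alone.

Measured in an ADME assay on HepG2 cells (Homo sapiens) for cytotoxicity, read by luminescence, with a stated time of 72 h; on this read-out higher numbers stand for an effect only at larger amounts of compound and lower numbers for an effect already at smaller amounts:
Compound 1 `CCOC(=O)c1c(-c2cccc(Oc3ccccc3)c2)[nH]c2cc(OC)c(F)cc2c1=O`: > 21500 nM, a limit
Compound 2 `CCOC(=O)c1c(-c2cccc(OC(F)(F)F)c2)[nH]c2cc(OC)c(F)cc2c1=O`: > 21500 nM, a limit
Compound 3 `CCOC(=O)c1c(-c2cccc(F)c2)[nH]c2cc(OC)c(F)cc2c1=O`: > 21500 nM, a limit

None of these three results is a number. Compound 3 has only a limit, (the limit of > 21500 nM in this assay, at which 3 of the 3 values shown sit), so its place among the others cannot be ranked.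

The next compound, compound 4 `CCOC(=O)c1c(-c2cccc(Cl)c2)[nH]c2cc(OC)c(F)cc2c1=O`, differs from compound 3 by one exchange: chloro in place of fluoro on an aromatic carbon. This puts chloro in place of fluoro on an aromatic carbon.

The measured steps nearest to this change are a step that the two limits leave unreadable from compound 2 to compound 3 and a step that the two limits leave unreadable from compound 1 to compound 3, and alongside them stands a step that the two limits leave unreadable from compound 1 to compound 2. Each changes the group at this same place, and none has a readable size. They give no size to carry over, so no step beyond the scatter is expected in this assay, and a further limit is the likeliest report. The expected step is a step that the limit leaves unreadable from compound 3 to compound 4.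

For compound 4 the estimated value is 30000 nM, with an expected range from 18000 nM to 60000 nM.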

Compound 4, half-maximal effective concentration: > 21500 nM
Compound 4: a limit, no number; the forecaster's own chance of this, stated with the estimate: 85%; the middle value is on the limit's open side.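

In this assay, for the compounds shown here, compound 4 gives > 21500 nM as a limit and not a number, so no new step between compound 4 and compound 1, compound 2 or compound 3 can be read. The compounds shown leave open whether they differ at all in this assay and at which concentration each would reach a half-maximal effect.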